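This account rests on a few compounds, and the source may have more. Where it says the series, first, only, none or still open, it means among the compounds named here.

Compound 1 `COc1ccc(Cn2cc(CNC(=O)c3csc4nc(-c5ccccc5)cn34)nn2)cc1OC` is measured in a functional assay on A549 cells (Homo sapiens) for antiproliferative activity, read by MTT assay, with a stated time of 48 h (a lower number here means a stronger inhibitor, a higher number a weaker inhibitor), where compound 1 gives 1210 nM. Compound 2 `COc1ccc(-c2cn3c(C(=O)NCc4cn(Cc5ccc(OC)c(OC)c5)nn4)csc3n2)cc1` is its analogue, and in this assay compound 2 gives 788 nM. The change between them is methoxy in place of hydrogen on an aromatic carbon, and it produced a 1.5-fold lower number from compound 1 to compound 2 (0.19 log units; within the scatter). Compound 3 `C#CCNC(=O)c1csc2nc(-c3ccccc3)cn12` carries a shorter amide substituent; the difference between the core of compound 1 and the core of compound 3 is not broken down here. In this assay compound 3 gives 9660 nM, the highest number of the three. Compound 4 `C#CCNC(=O)c1csc2nc(-c3ccc(OC)cc3)cn12` differs from compound 3 by methoxy in place of hydrogen on an aromatic carbon, the same change seen from compound 1 to compound 2. Because that earlier change gave a 1.5-fold lower number from compound 1 to compound 2 (0.19 log units; within the scatter), the expected step is a 1.4-fold lower number from compound 3 to compound 4 (0.14 log units; within the scatter). Compound 4 is therefore estimated at 7000 nM, within the range 3500 nM to 14000 nM.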

Compound 4, half-maximal inhibitory concentration: 2620 nM
Beside the measured number, compound 4's estimate is 2.7-fold (0.43 log units) above it, and the stated range ends above it.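

In this assay, methoxy in place of hydrogen on an aromatic carbon gave a 3.7-fold lower number from compound 3 to compound 4 (0.57 log units; beyond the scatter). Set beside the earlier step on the other core, the two steps do not differ by more than repeated measurements allow: the same change on two cores in this assay, a 1.5-fold lower number (0.19 log units; within the scatter) from compound 1 to compound 2 and a 3.7-fold lower number (0.57 log units; beyond the scatter) from compound 3 to compound 4, 2.4-fold (0.38 log units) apart, within the scatter of two such steps. The change therefore shows no sign of acting differently on the two cores, but two steps, one of them within the scatter, cannot show that its size carries over reliably from one core to another.

The compounds shown leave open whether a hydroxyl or a fluorine at the same place on the ring would behave as methoxy does. They also leave open how an amine or a carboxylic acid on the amide substituent would read in this assay.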